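The source may hold more compounds than are shown below. What is called first, only, known or untested is meant among the compounds shown, and "the series" means these compounds.

Working notes on the series. Compound 1 `CC(C)OC(=O)NCCS(=O)(=O)NC(=O)c1ccc(Nc2nc(NC3(c4ccc(Cl)cc4)CC3)nc(OCC(F)(F)F)n2)cc1` is the parent of the set here. In an ADME assay on microsomes from liver (Rattus norvegicus) for metabolic stability, with a stated time of 10 min (on this read-out lower numbers stand for a less stable compound and higher numbers for a more stable compound), compound 1 gives 73%, the lowest of the three numbers measured. Compound 2 `CC(C)(C)CNCCS(=O)(=O)NC(=O)c1ccc(Nc2nc(NC3(c4ccc(Cl)cc4)CC3)nc(OCC(F)(F)F)n2)cc1` gives 90% in this assay, and compound 3 `CS(=O)(=O)NC(=O)c1ccc(Nc2nc(NC3(c4ccc(Cl)cc4)CC3)nc(OCC(F)(F)F)n2)cc1` gives 85%. Both measured steps move upward from compound 1: a number 17 percentage points higher from compound 1 to compound 2 (beyond the scatter) and a number 12 percentage points higher from compound 1 to compound 3 (beyond the scatter), while a number 5 percentage points lower from compound 2 to compound 3 (within the scatter).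

The unmeasured compound 4 `CN(C)S(=O)(=O)NC(=O)c1ccc(Nc2nc(NC3(c4ccc(Cl)cc4)CC3)nc(OCC(F)(F)F)n2)cc1` differs from compound 1 as follows: dimethylamino in place of 2-((isopropoxycarbonyl)amino)ethyl on a sulfonyl sulfur. Going by the values given here, the step that bears most directly on this is the one to compound 3, where the group on the sulfonyl sulfur is cut back to hydrogen and the isopropoxycarbonyl-bearing chain is gone; the step to compound 2, which also removes the isopropoxycarbonyl unit, points the same way. Both steps are modest and upward, so a modest upward step is expected here as well, a number 12 percentage points higher from compound 1 to compound 4 (beyond the scatter). Compound 4 is therefore estimated at 85% in this assay, with a range from 72% to 95%.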

Compound 4, percent of the compound remaining: 76%
For compound 4 the middle estimate is 9 percentage points above the measured one, within the range that was stated.
By their numbers in this assay, from the lowest: compounds 1, 4, 3 and 2 (each within the scatter of the next, the first and the last beyond it).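

In this assay, losing the 2-((isopropoxycarbonyl)amino)ethyl group from the sulfonyl sulfur does not in itself separate a compound from the parent: with dimethylamino in its place, the change stays inside the scatter (a number 3 percentage points higher from compound 1 to compound 4 (within the scatter)). Dimethylamino also cannot be told apart from methyl at this position (a number 9 percentage points lower from compound 3 to compound 4 (within the scatter)), yet it stands clearly apart from 2-(neopentylamino)ethyl (a number 14 percentage points lower from compound 2 to compound 4 (beyond the scatter)), so the read-out here depends on the entering group as well as on the group that leaves. Nothing available on these compounds accounts for these differences.

Still open, as far as these compounds go, is whether a morpholine ring, a monomethylamino group or a longer alkyl chain on the sulfonyl sulfur would read closer to compound 1 or to compound 2. Also open, from the compounds shown here alone, is whether the dimethylamino result holds for other amines at this position.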